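This account rests on a few compounds, and the source may have more. Where it says the series, first, only, none or still open, it means among the compounds named here.

Among the compounds with values here, compound 1, with the structure `c1ccc(-c2cc(-c3ccccn3)nc(-c3ccccn3)c2)cc1`, is the more potent of the two compounds measured so far: in a functional assay on A549 cells (Homo sapiens) for antiproliferative activity (on this read-out higher numbers stand for weaker inhibition of growth and lower numbers for stronger inhibition of growth), compound 1 gives 0.56 ug/mL. Compound 2, with the structure `c1ccc(-c2cc(-c3cccs3)cc(-c3ccncc3)n2)nc1`, gives 36.2 ug/mL in this assay, a much higher number than compound 1; the two structures differ in more than one place, so that gap cannot be tied to any single change.

Compound 3, with the structure `c1ccc(-c2cc(-c3cccnc3)nc(-c3ccccn3)c2)cc1`, differs from compound 1 in one place: pyridin-3-yl in place of pyridin-2-yl on an aromatic carbon. Within the data shown here, no measured pair in this set isolates this kind of change, so the size of its effect is not known from the data. The step from compound 1 to compound 3 is expected to be moderate and toward weaker growth inhibition, a 5.4-fold higher number from compound 1 to compound 3 (0.73 log units; beyond the scatter), reaching beyond the usual scatter. Compound 3 is therefore estimated at 3 ug/mL in this assay, with a likely range from 0.5 ug/mL to 20 ug/mL.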

Compound 3, concentration for 50% growth inhibition: 44.8 ug/mL
Estimate against measurement, compound 3: 15-fold (1.17 log units) below; the measured number lies above the stated range.
By their numbers in this assay, from the lowest: compound 1; then compounds 2 and 3 (each within the scatter of the next).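

In this assay, within the data shown here, pyridin-3-yl in place of pyridin-2-yl gives an 80-fold higher number from compound 1 to compound 3 (1.90 log units; beyond the scatter), the first measured step that changes one place only. The two groups have the same atoms and the same counts of hydrogen-bond donors and acceptors, so at this position a difference in how the ring is joined is enough to separate strong from much weaker growth inhibition. No measurement shown here accounts for the size of this step.

The compounds shown leave open whether the remaining pyridin-2-yl group is equally demanding when its ring is joined differently. Also open, as far as these compounds go, is whether a pyridin-2-yl ring carrying a methoxy group or an amine at this position would keep the growth inhibition of compound 1.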